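Aryl variation on the saturated ring carbon: clearance notes

The source may report more compounds than this note shows. Statements on the series, on what has been measured and on what is new or still open speak of the compounds shown alone.

In an ADME assay on cells (Hepatocyte, Homo sapiens) for pharmacokinetics (on this read-out higher numbers stand for fast clearance and lower numbers for slow clearance), compound 3 `COc1nc(C2=NOCC(c3cccc(C4CC4)c3)N2)ccc1-n1cnc(C)c1` gives 29 mL/min/kg, the lowest of the three numbers measured. Compound 1 `COc1nc(C2=NOCC(c3ccc(C)cc3)N2)ccc1-n1cnc(C)c1` gives 135 mL/min/kg and compound 2 `COc1nc(C2=NOCC(c3ccc(C(C)(C)C)cc3)N2)ccc1-n1cnc(C)c1` gives 320 mL/min/kg. The steps of a 4.7-fold lower number from compound 1 to compound 3 (0.67 log units; beyond the scatter) and an 11-fold lower number from compound 2 to compound 3 (1.04 log units; beyond the scatter) both exchanged the aryl group on the saturated ring carbon and lowered the number, whereas a 2.4-fold higher number from compound 1 to compound 2 (0.37 log units; beyond the scatter) raised it. Compound 4 `COc1nc(C2=NOCC(c3cc(Cl)cc(Cl)c3)N2)ccc1-n1cnc(C)c1` differs from compound 3 by 3,5-dichlorophenyl in place of 3-cyclopropylphenyl on a saturated ring carbon. No 3,5-dichlorophenyl analogue has been measured, so the expectation rests on the aryl exchanges already seen, which ran in both directions and were modest to large. A modest rise beyond the scatter is expected for compound 4 in this assay, a 1.7-fold higher number from compound 3 to compound 4 (0.24 log units; within the scatter). The estimate for compound 4 is 50 mL/min/kg, with a range from 20 mL/min/kg to 130 mL/min/kg.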

Compound 4, clearance: 85 mL/min/kg
Compound 4: the middle estimate sits 1.7-fold (0.23 log units) below what was measured; the range from low to high includes it.
By their numbers in this assay, from the lowest: compound 3; then compounds 4 and 1 (each within the scatter of the next); then compound 2.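

In this assay, 3,5-dichlorophenyl does not match the low number given by 3-cyclopropylphenyl (a 2.9-fold higher number from compound 3 to compound 4 (0.47 log units; beyond the scatter)), so compound 3 stays lowest of the four. The exchange from 4-(tert-butyl)phenyl still lowers the number (a 3.8-fold lower number from compound 2 to compound 4 (0.58 log units; beyond the scatter)), whereas the exchange from 4-methylphenyl stays within the scatter (a 1.6-fold lower number from compound 1 to compound 4 (0.20 log units; within the scatter)), which leaves those two aryl groups unseparated at this position. Nothing available explains these differences between aryl groups.

Open, on these data alone, is whether the cyclopropyl group itself accounts for the number of compound 3. Also open, as far as these compounds go, is how an aryl group bearing an amine or a carboxylic acid would read on this saturated ring carbon.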